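Aryl Amides at the Toxicity Ceiling and a Piperidinyl Successor

This account rests on a few compounds, and the source may have more. Where it says the series, first, only, none or still open, it means among the compounds named here.

Compound 1 `COc1ccc(-c2cnc(NC(=O)c3cccnc3)n2C)cc1` carries a pyridin-3-yl group on the carbonyl carbon of its amide. In a toxicity assay on THP-1 cells (Homo sapiens) for inhibition (on this read-out lower numbers stand for higher toxicity in this test and higher numbers for lower toxicity in this test), compound 1 gives > 100000 nM, which is a limit of the assay and not a number. Compound 2 `COc1ccc(C(=O)Nc2ncc(-c3ccc(OC)cc3)n2C)cc1` and compound 3 `COc1ccc(-c2cnc(NC(=O)c3ccc(C)cc3)n2C)cc1` carry 4-methoxyphenyl and 4-methylphenyl in that place. In this assay compound 2 gives > 100000 nM, again a limit. In this assay compound 3 gives > 100000 nM, also a limit. Compound 3 thus stands where both other compounds stand, at the limit of > 100000 nM in this assay, at which 3 of the 3 values shown sit. The steps among these three, a step that the two limits leave unreadable from compound 1 to compound 2, a step that the two limits leave unreadable from compound 1 to compound 3 and a step that the two limits leave unreadable from compound 2 to compound 3, accordingly show no readable size. Compound 4 `COc1ccc(-c2cnc(NC(=O)C3CCNCC3)n2C)cc1` arises from compound 3 by piperidin-4-yl in place of 4-methylphenyl on a carbonyl carbon. Among the measured compounds shown here, no measured step reaches past the limit, so no size can be drawn from them for this change, and compound 4 is expected to remain at the limit with a step of a number no higher from compound 3 to compound 4 (the limit leaves the size open) that is itself expected to stay unreadable. The estimate for compound 4 is 100000 nM, within 50000 nM to 200000 nM.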

Compound 4, half-maximal cytotoxic concentration: > 100000 nM
Compound 4: only a limit was reported (the forecaster's own chance of this, stated with the estimate: 85%); the middle value lies on the limit itself.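

Among the compounds shown here, compound 4 sits at the limit, as do compound 1, compound 2 and compound 3, so no step to compound 4 can be read in this assay here. The compounds shown leave open whether piperidin-4-yl and the three aromatic groups on the carbonyl carbon differ in toxicity at all.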